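The source may hold more compounds than are shown below. What is called first, only, known or untested is meant among the compounds shown, and "the series" means these compounds.

Of the compounds shown here, three that share one core have so far been measured in an assay on CHO cells for displacement of a labelled ligand from adenosine receptor A3 (Homo sapiens), read by scintillation counting, with a stated time of 120 min, tested at 10 uM; a higher number here means more inhibition at the concentration tested (going by the name of the read-out), a lower number less inhibition. Compound 1 `CC(C)N1CCN(Cc2csc(N)c2C(=O)c2ccc(Cl)cc2)CC1` gives 0% in this assay. Compound 2 `COc1ccc(N2CCN(Cc3csc(N)c3C(=O)c3ccc(Cl)cc3)CC2)cc1` gives 0%. Compound 3 `Nc1scc(CN2CCN(c3cccc(C(F)(F)F)c3)CC2)c1C(=O)c1ccc(Cl)cc1` gives 0%. The steps of no change at the digits printed from compound 1 to compound 2 (within the scatter), no change at the digits printed from compound 1 to compound 3 (within the scatter) and no change at the digits printed from compound 2 to compound 3 (within the scatter) all describe replacements on the same amine nitrogen in a ring, and none of them moves the read-out beyond the scatter. Compound 3 therefore stands level with compound 1 and compound 2 at the digits shown, with nothing in the numbers to separate the three.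

Compound 4 `Nc1scc(CN2CCN(C3CCCCCC3)CC2)c1C(=O)c1ccc(Cl)cc1` has not yet been measured. It differs from compound 3 in one place: cycloheptyl in place of 3-(trifluoromethyl)phenyl on an amine nitrogen in a ring. The replacement again sits on the amine nitrogen in a ring where the three measured steps sat. Those steps, from isopropyl to 4-methoxyphenyl, from isopropyl to 3-(trifluoromethyl)phenyl and between the two aryl groups, were all flat, so no step beyond the scatter is expected in this assay for no change at the digits printed from compound 3 to compound 4 (within the scatter). Because compound 3 gives 0%, the value expected for compound 4 in this assay is 0%, with a range from -10% to 12%.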

Compound 4, a percentage reported as inhibition, at one concentration (the size of the read-out at that concentration, not a potency): 0%
Compound 4: middle estimate and measured number agree at the digits printed; the measured number falls inside the stated range.
By their numbers in this assay, from the lowest: compounds 1, 2, 3 and 4 (each within the scatter of the next).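

Replacing the aryl group on the amine nitrogen with cycloheptyl, a seven-membered non-aromatic ring of carbon only, gives no change at the digits printed from compound 3 to compound 4 (within the scatter) in this assay. The same group in place of the other two substituents gives no change at the digits printed from compound 2 to compound 4 (within the scatter) and no change at the digits printed from compound 1 to compound 4 (within the scatter), so a cyclic non-aromatic carbon group now joins isopropyl and the two substituted phenyl groups at this position, and compound 4 stands at 0% with them. No independent measurement is available to explain why these four substituents read alike in this assay.

With all four values level, the compounds shown do not reveal whether any group on this nitrogen can raise the read-out, for instance a carboxylic acid or a primary amine carried on a longer chain, or a benzyl group. They also leave open whether a change elsewhere on the shared core would move the read-out in this assay, and whether these compounds would show any inhibition at a higher concentration.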